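The compounds below may be only part of what the source reports. "The series", "measured", "known", "first", "only" and "open" are said of these compounds alone.

Measured so far:
- compound 1 `O=C(Nc1ccc(Cl)c(-c2nnc3c(Cl)cccn23)c1)c1c(F)cccc1Cl`: 72300 nM
- compound 2 `O=C(Nc1ccc(Cl)c(-c2nnc3c(Cl)cccn23)c1)c1ccc(Cl)cc1Cl`: 61300 nM

In a functional assay on A549 cells (Homo sapiens) for antiproliferative activity, read by MTT assay, with a stated time of 72 h (on this read-out higher numbers stand for weaker inhibition and lower numbers for stronger inhibition), compound 1 gives 72300 nM and compound 2 gives 61300 nM. Compound 2 carries the lower of the two numbers, but the step of a 1.2-fold lower number from compound 1 to compound 2 (0.07 log units; within the scatter) lies within the scatter, so the two compounds stand level and neither can be called the stronger. Both sit at the weak end of inhibition.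

Compound 3 `CS(=O)(=O)c1cccc(C(=O)Nc2ccc(Cl)c(-c3nnc4c(Cl)cccn34)c2)c1` has not been measured. Within the data shown here, it differs from compound 2 by 3-(methylsulfonyl)phenyl in place of 2,4-dichlorophenyl on a carbonyl carbon, the same carbonyl carbon carrying the change as in the only measured step.

That single step, a 1.2-fold lower number from compound 1 to compound 2 (0.07 log units; within the scatter), exchanges one chlorinated phenyl for another and gives no information on a methylsulfonyl-bearing phenyl. Among the measured compounds shown here, no measured pair bears directly on this change. With the two measured compounds both weak and level, the working expectation is that compound 3 stays near them, with an expected step of a 1.3-fold higher number from compound 2 to compound 3 (0.12 log units; within the scatter) and no movement beyond the scatter. Compound 3 is estimated at 80000 nM, within a range from 20000 nM to 300000 nM.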

Compound 3, half-maximal inhibitory concentration: > 100000 nM
Compound 3: a limit, no number; the forecaster's own chance of this, stated with the estimate: 20%; at least 1.2-fold (0.09 log units) between middle value and limit.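

Compound 3 gives a limit, not a number, in this assay: the limit of > 100000 nM in this assay, at which 1 of the 3 values shown sits.

The readable steps are floors only, an at least 1.6-fold higher number from compound 2 to compound 3 (0.21 log units; that floor lies within the scatter) and an at least 1.3-fold higher number from compound 1 to compound 3 (0.14 log units; that floor lies within the scatter), so neither separates compound 3 from the two measured compounds, and no loss can be claimed from them. What is new is that the series now includes a phenyl without halogen on this carbonyl carbon: 3-(methylsulfonyl)phenyl carries hydrogen-bond acceptors where 2,4-dichlorophenyl carries none, and this exchange still gives no measured number in a stronger range, leaving all three compounds at the weak end of the read-out.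

On these data alone, how far compound 3 lies past its limit stays unknown, and with it the true size of both steps. Also open, as far as these compounds go, is whether an amine, a carboxylic acid or a longer chain in place of the phenyl on this carbonyl carbon would bring a clear movement in this assay, and whether any such movement would depend on the group's place on the ring.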